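The source may hold more compounds than are shown below. What is called first, only, known or untested is meant among the compounds shown, and "the series" means these compounds.

Measured in a functional assay on HT-29 cells (Homo sapiens) for inhibition; a higher number here means a weaker inhibitor, a lower number a stronger inhibitor:
- compound 1 `COc1cc(/C=C\c2ccc3[nH]ccc3c2)cc(OC)c1OC`: 35 nM
- compound 2 `COc1cc(/C=C/c2ccc3c(ccn3C)c2)cc(OC)c1OC`: 280 nM

Compound 2 has the higher of the two numbers, which makes it the weaker inhibitor, and its gap to compound 1 lies beyond the scatter. Compound 3 `COc1cc(/C=C\c2ccc3c(ccn3C)c2)cc(OC)c1OC` has not yet been measured. It keeps the atoms and bonds of compound 2: the two compounds have the same atoms and bonds and differ only in configuration as drawn: 1 of 1 stereo elements differ; a double bond is drawn E in compound 2 and Z in compound 3. Compound 1 also has its double bond drawn Z and gives 35 nM, so a large fall in the number, beyond the scatter, is expected in this assay. The expected change is a 9.3-fold lower number from compound 2 to compound 3 (0.97 log units; beyond the scatter). For compound 3 the estimated value is 30 nM, with an estimated range of 8 nM to 120 nM.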

Compound 3, half-maximal inhibitory concentration: 360 nM
For compound 3 the middle estimate is 12-fold (1.08 log units) below the measured one, and the stated range ends below it.
By their numbers in this assay, from the lowest: compound 1; then compounds 2 and 3 (each within the scatter of the next).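

In this assay, redrawing the double bond from E to Z gives a 1.3-fold higher number from compound 2 to compound 3 (0.11 log units; within the scatter), so with a methyl on the aromatic nitrogen, the geometry of that bond shows no effect beyond the scatter. The Z form alone therefore does not bring a low number. Methyl in place of hydrogen on an aromatic nitrogen, the single change between the two Z compounds, gives a 10-fold higher number from compound 1 to compound 3 (1.01 log units; beyond the scatter). Open, from the compounds shown here alone, is whether the double bond's geometry matters when that nitrogen carries hydrogen. Also open, going by these compounds, is how an ethyl group on that nitrogen would compare.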